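The compounds below may be only part of what the source reports. "The series", "measured", "known", "first", "only" and "open" are said of these compounds alone.

Compound 1 `Cc1cccc2sc(NC(=O)COc3ccc(/C=C4\SC(=O)NC4=O)cc3)nc12` gives > 100000 nM in a functional assay on KB cells (Homo sapiens) for inhibition (on this read-out lower numbers stand for stronger inhibition of growth and higher numbers for weaker inhibition of growth), a limit of the assay. Compound 2 `O=C(COc1ccc(/C=C2\SC(=O)NC2=O)cc1)Nc1ccc([N+](=O)[O-])cc1` gives > 100000 nM, again a limit. Compound 3 `O=C(COc1ccc(/C=C2\SC(=O)NC2=O)cc1)Nc1ccc(F)cc1` gives > 100000 nM, also a limit.

Compound 3 thus stands at the same limit as the other two, with no number of its own. Compound 4 `Cc1cc(Br)ccc1NC(=O)COc1ccc(/C=C2\SC(=O)NC2=O)cc1` differs from it in one place: 4-bromo-2-methylphenyl in place of 4-fluorophenyl on an amide-type nitrogen. Within the data shown here, the only single-site step measured, a step that the two limits leave unreadable from compound 2 to compound 3, bears on an aromatic substituent of the same ring and gives no readable size, because of the limit of > 100000 nM in this assay, at which 3 of the 3 values shown sit. Among the measured compounds shown here, no measured step therefore fixes a direction, and the same outcome is expected for compound 4, whose value is estimated at 150000 nM (range 30000 nM to 800000 nM), an expected step that the limit leaves unreadable from compound 3 to compound 4.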

Compound 4, concentration for 50% growth inhibition: > 100000 nM
Compound 4 was reported as a limit; the forecaster's own chance of this, stated with the estimate: 80%; the middle value is on the limit's open side.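

Neither the step from compound 3 to compound 4 nor the one from compound 2 to compound 4 can be read, because all the values sit at one limit: the limit of > 100000 nM in this assay, at which 4 of the 4 values shown sit.

The compounds shown leave open whether these groups on the amide-type nitrogen differ in growth inhibition at all.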